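Swapping isobutyl for cyclobutyl on the amide carbonyl

The source may hold more compounds than are shown below. What is called first, only, known or untested is meant among the compounds shown, and "the series" means these compounds.

Compound 1, `Cc1cccc(Cn2c(CN3CCN(C(=O)CC(C)C)CC3)nc3ccccc32)c1`, gives 71.4% in an assay on isolated protein for inhibition of aldehyde dehydrogenase 1A1 (Homo sapiens), read by spectrophotometry, tested at 10 uM; a lower number here means less inhibition, a higher number more inhibition at the concentration tested (going by the name of the read-out).
Compound 2, `O=C(C1CC1)N1CCN(Cc2nc3ccccc3n2CC2CCCC2)CC1`, gives 44.5% in this assay.
Compound 3, `Cc1ccccc1Cn1c(CN2CCN(C(=O)C3CC3)CC2)nc2ccccc21`, gives 29.1% in this assay.

Compound 1 stands highest of the three measured numbers, beyond the scatter above both compound 2 and compound 3. Compound 4, `Cc1cccc(Cn2c(CN3CCN(C(=O)C4CCC4)CC3)nc3ccccc32)c1`, has not yet been measured; it differs from compound 1 in one place: cyclobutyl in place of isobutyl on a carbonyl carbon.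

Going by the values given here, the one measured step, a number 15.4 percentage points lower from compound 2 to compound 3 (beyond the scatter), concerns the group on the saturated chain carbon bound to the aromatic nitrogen, not the group on the carbonyl carbon, so it does not speak directly to this change. Among the compounds with values here, compound 2 and compound 3 both carry cyclopropyl on the carbonyl carbon and give lower numbers than compound 1, but each also differs from compound 1 elsewhere, so no step isolates the carbonyl substituent. Isobutyl and cyclobutyl are counted alike in heavy atoms, donors and acceptors, so a step no larger than the scatter, or a small fall, is expected in this assay. Compound 4 is therefore estimated at 62%, between 42% and 80%, an expected step of a number 9.4 percentage points lower from compound 1 to compound 4 (within the scatter).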

Compound 4, a percentage reported as inhibition, at one concentration (the size of the read-out at that concentration, not a potency): 69.1%
The estimate for compound 4 lay 7.1 percentage points below the measured number; measured number inside the range.
By their numbers in this assay, from the lowest: compound 3; then compound 2; then compounds 4 and 1 (each within the scatter of the next).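

In this assay the numbers show a number 2.3 percentage points lower from compound 1 to compound 4 (within the scatter) when cyclobutyl replaces isobutyl on the carbonyl carbon, so here an open group and a ring with the same count of heavy atoms cannot be told apart. Going by these compounds alone, this is the first comparison that isolates the group on the carbonyl carbon, as the earlier step concerned the group on the saturated chain carbon, and compound 2 and compound 3 differ from compound 1 in more than one place. Nothing measured here explains why the two groups give numbers so alike.

As far as these compounds go, what cyclopropyl on the carbonyl carbon would give with everything else in compound 1 kept the same remains open. So does whether a longer chain, an amine or a carboxylic acid at this place would leave the number unchanged.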